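A Single Methyl Addition and Its Expected Effect on Response

A few compounds are considered here, and "the series" means these few. Any claim that something is new, unique, unknown or untested is made for them only; others in the source may bear on it.

Of the compounds shown here, two have so far been tested in a functional assay on CHO cells for agonist activity at G-protein coupled receptor 52 (Homo sapiens), read by AlphaScreen and cAMP accumulation, with a stated time of 30 min; on this read-out lower numbers stand for smaller maximal responses and higher numbers for larger maximal responses. Compound 1, `O=C(NCCO)c1cccc(-c2cccc3cc(Cc4cccc(C(F)(F)F)c4)oc23)c1`, reaches a maximal response of 74.8% in this assay. Compound 2, `O=C(NCCO)c1cccc(-c2cccc3cn(Cc4cccc(C(F)(F)F)c4)nc23)c1`, has a related but different core and gives 69.7%. These two numbers lie within the usual scatter of each other, so no order can be read between them; compound 1 simply has the higher of the two numbers shown.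

Compound 3, `Cc1c(Cc2cccc(C(F)(F)F)c2)oc2c(-c3cccc(C(=O)NCCO)c3)cccc12`, has not been measured. It differs from compound 1 in one place: methyl in place of hydrogen on an aromatic carbon. Among the measured compounds shown here, no step between two measured compounds that differ in a single place is available, so there is no direct guide to how such a change moves the maximal response. What the data do show is that compound 1 at 74.8% and compound 2 at 69.7% stay within the scatter despite a change in the core, so a single methyl is expected to do no more. The implied step, a number 2.8 percentage points lower from compound 1 to compound 3 (within the scatter), is expected to stay within the scatter. Compound 3 is therefore estimated to reach 72%, within a range from 55% to 90%.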

Compound 3, largest response reached (Emax), in percent of the reference or control that the assay uses: 71.5%
Beside the measured number, compound 3's estimate is 0.5 percentage points above it; low and high end bracket the measured number.
By their numbers in this assay, from the lowest: compounds 2, 3 and 1 (each within the scatter of the next).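

Among the compounds shown here, this is the first step where only one place differs: methyl in place of hydrogen on an aromatic carbon of the five-membered aromatic ring with 1 oxygen, next to the ring atom that bears a 3-(trifluoromethyl)benzyl group, gives a number 3.3 percentage points lower from compound 1 to compound 3 (within the scatter) in this assay. For the compounds shown here, this position therefore takes one added carbon without any shift in the maximal response that can be told apart from the scatter, something the earlier compounds could not show, as they offered no single-place step. Nothing measured here offers an explanation for this result.

The compounds shown leave open whether the same holds for other groups at this position, such as an ethyl group, a chlorine atom, a methoxy group or an amine. A single methyl at a single position also cannot tell how the same swap would behave on the other aromatic carbons of the shared core, so this step should not be read as a rule for the whole series.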